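The compounds below may be only part of what the source reports. "The series", "measured", "known", "first", "only" and "open" are said of these compounds alone.

Compound 1 `CCOc1ccc2c(=O)cc(CC)oc2c1CBr` has only a limit in a functional assay on KB cells (Homo sapiens) for antiproliferative activity, read by sulforhodamine B assay, with a stated time of 72 h; on this read-out lower numbers stand for stronger inhibition of growth and higher numbers for weaker inhibition of growth: in this assay compound 1 gives > 32100 nM. Compound 2 `CCOc1ccc2c(=O)cc(C(C)Br)oc2c1CBr` gives 15600 nM in this assay.

Compound 2 therefore stands as the only number shown; the other value is a limit, and the limit of > 32100 nM in this assay, at which 1 of the 2 values shown sits, is what that limit amounts to. Within the data shown here, the one measured step is an at least 2.0-fold lower number from compound 1 to compound 2 (0.31 log units; beyond the scatter), and it concerns a chain carbon bound to the aromatic carbon, not the alkoxy side.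

Compound 3 `CC(C)COc1ccc2c(=O)cc(C(C)Br)oc2c1CBr` differs from compound 2 by isopropyl in place of methyl on a saturated chain carbon bound to an oxygen on an aromatic ring. Among the measured compounds shown here, no measured step touches that position: the single step from compound 1 to compound 2 changes a different part of the core, so it offers no guide to the size or direction of this step. With nothing to lean on, the expectation for compound 3 is a step of a 1.0-fold lower number from compound 2 to compound 3 (0.02 log units; within the scatter), that is, no change beyond the scatter. Compound 3 is accordingly estimated at 15000 nM in this assay, with a range from 6000 nM to 40000 nM.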

Compound 3, concentration for 50% growth inhibition: 10900 nM
Estimate against measurement, compound 3: 1.4-fold (0.14 log units) above; low and high end bracket the measured number.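

Among these compounds, the first reading on the alkoxy side of the core comes from replacing ethoxy with isobutoxy, and in this assay this gives a 1.4-fold lower number from compound 2 to compound 3 (0.16 log units; within the scatter), so the two compounds cannot be told apart on this read-out. The position on a saturated chain carbon bound to an oxygen on an aromatic ring therefore accepts the branched isobutoxy group in place of ethoxy, with growth inhibition kept at the level of compound 2, whereas the earlier step had spoken only for the chain carbon bound to the aromatic carbon. Nothing measured here offers an explanation for why this exchange leaves the read-out where it stands.

Going by these compounds, it remains open whether a longer straight chain, a cyclopropylmethyl group, or an amine or a carboxylic acid at the end of this chain would move the number beyond the scatter. On these data alone, compound 1 gives only a limit, > 32100 nM, so it also remains open how isobutoxy would read on a core without the bromo on the ethyl chain.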